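Cytotoxicity of Amidine Derivatives: From Aryl to Isopropyl Amine

A few compounds are considered here, and "the series" means these few. Any claim that something is new, unique, unknown or untested is made for them only; others in the source may bear on it.

Measured compounds:
- compound 1 `Cc1ccc(S(=O)(=O)/N=C(/CCNC2=CC(=O)c3ccccc3C2=O)Nc2ccc(Cl)cc2)cc1`: 32400 nM
- compound 2 `Cc1ccc(S(=O)(=O)/N=C(/CCNC2=CC(=O)c3ccccc3C2=O)Nc2cccc(C)c2)cc1`: 10200 nM
- compound 3 `Cc1ccc(S(=O)(=O)/N=C(/CCNC2=CC(=O)c3ccccc3C2=O)Nc2cc(F)c(F)c(F)c2)cc1`: 12600 nM

The three measured compounds share one core and differ only in the group on the amine nitrogen. In a functional assay on DU-145 cells (Homo sapiens) for cytotoxicity, read by MTT assay, with a stated time of 48 h (on this read-out higher numbers stand for weaker inhibition and lower numbers for stronger inhibition), compound 1 gives the highest number of the three. The two measured steps away from it are both modest: a 3.2-fold lower number from compound 1 to compound 2 (0.50 log units; beyond the scatter) and a 2.6-fold lower number from compound 1 to compound 3 (0.41 log units; beyond the scatter). Between the other two, a 1.2-fold higher number from compound 2 to compound 3 (0.09 log units; within the scatter), so compound 3 stands second of three, close to compound 2 and separated from compound 1.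

Compound 4 `Cc1ccc(S(=O)(=O)/N=C(/CCNC2=CC(=O)c3ccccc3C2=O)NC(C)C)cc1` is the unmeasured compound. The change from compound 3 is isopropyl in place of 3,4,5-trifluorophenyl on an amine nitrogen. Neither measured step bears on this change directly: both exchange one substituted phenyl for another on the same nitrogen, whereas here a ring is exchanged for an acyclic alkyl group. The measured steps do show that the group on this nitrogen moves the read-out only modestly among the three compounds.

On that basis, compound 4 is expected to stay in the range of the aryl compounds, with a step of a 1.3-fold higher number from compound 3 to compound 4 (0.10 log units; within the scatter) from compound 3. Compound 4 is therefore estimated at 16000 nM, within 5000 nM to 50000 nM.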

Compound 4, half-maximal inhibitory concentration: 28500 nM
For compound 4 the middle estimate is 1.8-fold (0.25 log units) below the measured one, and the stated range covers the measured number.
By their numbers in this assay, from the lowest: compounds 2 and 3 (each within the scatter of the next); then compounds 4 and 1 (each within the scatter of the next).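

In this assay, within the data shown here, isopropyl is the only group among the four with no ring on the amine nitrogen, and what it does depends on the aryl group it replaces: it gives a 2.3-fold higher number from compound 3 to compound 4 (0.35 log units; beyond the scatter) when it replaces 3,4,5-trifluorophenyl and a 2.8-fold higher number from compound 2 to compound 4 (0.45 log units; beyond the scatter) when it replaces 3-methylphenyl, but a 1.1-fold lower number from compound 1 to compound 4 (0.06 log units; within the scatter) when it replaces 4-chlorophenyl. A ring on this nitrogen therefore does not set the number by itself, as compound 1 with its ring and compound 4 without one stand within the scatter of each other, while compound 2 and compound 3, which also carry rings, stand apart from both. Nothing at hand gives a reason for this dependence on the aryl group.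

The compounds shown leave open whether isopropyl speaks for alkyl groups in general or only for itself, which a straight propyl chain, a cyclohexyl ring or a benzyl group on the same nitrogen would test. They also leave open how an aryl group carrying a methoxy or a nitrile would compare.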